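Methyl for Hydrogen on a Hydrazone Series with Three Limits

The compounds below may be only part of what the source reports. "The series", "measured", "known", "first", "only" and "open" are said of these compounds alone.

Compound 1, `COc1ccccc1N/N=C1\CCC(C)n2c1ncc(C(=O)O)c2=O`, in a functional assay on the whole organism for inhibition, with Rattus norvegicus as the target; a higher number here means that more compound is needed for the effect, a lower number that less compound is needed: > 1000 umol/kg, a limit of the assay.
Compound 2, `CCOc1ccccc1N/N=C1\CCC(C)n2c1ncc(C(=O)O)c2=O`, in this assay: > 1000 umol/kg, a limit of the assay.
Compound 3, `CCc1ccc(N/N=C2\CCC(C)n3c2ncc(C(=O)O)c3=O)cc1`, in this assay: > 1000 umol/kg, a limit of the assay.

The change from compound 1 to compound 2, (methyl in place of hydrogen on a saturated chain carbon bound to an oxygen on an aromatic ring), gave a step that the two limits leave unreadable from compound 1 to compound 2. The cores of compound 1 and compound 3 differ by 4-ethylphenyl in place of 2-methoxyphenyl on an amine nitrogen, with a step that the two limits leave unreadable from compound 1 to compound 3. Compound 4, `CC(C)c1ccc(N/N=C2\CCC(C)n3c2ncc(C(=O)O)c3=O)cc1`, is not yet measured; it differs from compound 3 by methyl in place of hydrogen on a saturated chain carbon bound to an aromatic carbon and a saturated chain carbon. This is the same kind of change as from compound 1 to compound 2, though the place differs: there the carbon is bound to an oxygen on an aromatic ring, here to an aromatic carbon and a saturated chain carbon. Among the compounds with values here, every value rests at the limit of > 1000 umol/kg in this assay, at which 3 of the 3 values shown sit, so no step is readable. Compound 4 is expected to give 1500 umol/kg in this assay, between 500 umol/kg and 5000 umol/kg. The step that the limit leaves unreadable from compound 3 to compound 4 is an estimate, resting only on compound 3 at > 1000 umol/kg and on the three shared limits.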

Compound 4, dose for 50% inhibition: > 100 umol/kg
Compound 4 gave a limit, no number; the forecaster's own chance of this, stated with the estimate: 85%; the middle value lies beyond the limit too.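

Within the data shown here, compound 3 and compound 4 both gave only limits in this assay, so no step between them can be read. The compounds shown leave open at what dose any of them reaches the effect, and whether methyl in place of hydrogen changes that dose.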